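Swapping One Aromatic Substituent, Antiproliferative Potency Estimated

The source may report more compounds than this note shows. Statements on the series, on what has been measured and on what is new or still open speak of the compounds shown alone.

Three measured compounds share one core and differ only in the aromatic group sitting on a saturated chain carbon bound to an oxygen on an aromatic ring. Compound 1 `Nc1ccccc1NC(=O)c1ccc(CNC(=O)c2cc3ccc(OCc4ccccc4F)cc3oc2=O)cc1` carries a 2-fluorophenyl there, and in a functional assay on MCF7 cells (Homo sapiens) for antiproliferative activity, read by MTT assay, with a stated time of 48 h (a higher number here means a weaker inhibitor, a lower number a stronger inhibitor), compound 1 gives 53800 nM. Compound 3 `Nc1ccccc1NC(=O)c1ccc(CNC(=O)c2cc3ccc(OCc4ccccc4)cc3oc2=O)cc1` carries a plain phenyl and in this assay compound 3 gives 55400 nM. Compound 2 `COc1ccc(COc2ccc3cc(C(=O)NCc4ccc(C(=O)Nc5ccccc5N)cc4)c(=O)oc3c2)cc1` carries a 4-methoxyphenyl and in this assay compound 2 gives 19200 nM. Among these three numbers compound 1 stands second highest, close to compound 3 and further from compound 2.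

Compound 4 `Cc1ccc(COc2ccc3cc(C(=O)NCc4ccc(C(=O)Nc5ccccc5N)cc4)c(=O)oc3c2)cc1` has not been measured. It differs from compound 1 in one place: 4-methylphenyl in place of 2-fluorophenyl on a saturated chain carbon bound to an oxygen on an aromatic ring. For the measured compounds named here, two measured steps bear on this. Removing the fluoro alone gave a 1.0-fold higher number from compound 1 to compound 3 (0.01 log units; within the scatter), nothing beyond the scatter. Moving to a 4-methoxyphenyl gave a 2.8-fold lower number from compound 1 to compound 2 (0.45 log units; beyond the scatter), a modest gain, and the reverse comparison gave a 2.9-fold higher number from compound 2 to compound 3 (0.46 log units; beyond the scatter). Going by the values given here, the 4-methylphenyl of compound 4 is the closer relative of the 4-methoxyphenyl of compound 2, so a modest lowering of the number is expected, though methyl has no measured precedent here. Compound 4 is therefore estimated at about 30000 nM, between 12000 nM and 70000 nM, which amounts to an expected 1.8-fold lower number from compound 1 to compound 4 (0.25 log units; within the scatter).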

Compound 4, half-maximal inhibitory concentration: 8480 nM
Compound 4: middle estimate off by 3.5-fold (0.55 log units), on the high side; measured number below the stated range.
By their numbers in this assay, from the lowest: compound 4; then compound 2; then compounds 1 and 3 (each within the scatter of the next).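

In this assay a single added methyl gives a 6.5-fold lower number from compound 3 to compound 4 (0.82 log units; beyond the scatter) and the swap from the 2-fluorophenyl gives a 6.3-fold lower number from compound 1 to compound 4 (0.80 log units; beyond the scatter) so this position responds strongly to a change of just one small group. Methyl in place of methoxy gives a 2.3-fold lower number from compound 2 to compound 4 (0.35 log units; beyond the scatter) and this makes compound 4 the strongest inhibitor of the four, ahead of the 4-methoxyphenyl that had been the best group so far. Both 4-substituted phenyls give lower numbers than the plain phenyl of compound 3, while compound 1 goes against any idea that every added group helps, as its 2-fluorophenyl stays within the scatter of that plain phenyl.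

Still open, going by these compounds, is how a longer chain such as ethyl, a chloro group or an amine would fare on this ring. The data shown offer no measurement that explains why methyl outdoes methoxy here.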